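The source may hold more compounds than are shown below. What is called first, only, known or untested is meant among the compounds shown, and "the series" means these compounds.

Among the compounds with values here, in an in vitro functional assay on CHO/Galpha16 cells for antagonist activity at C-C chemokine receptor type 8 (Homo sapiens), read by FLIPR (a lower number here means a stronger inhibitor, a higher number a weaker inhibitor), compound 3 `CCCC(=O)N1CCC(NS(=O)(=O)c2ccc(NC(=O)c3nccn3C)c3ccccc23)CC1` gives 20.4 nM, the second highest of the three numbers known. Compound 1 `CCCC(=O)N1CCC(NS(=O)(=O)c2ccc(NC(=O)c3ccccc3)c3ccccc23)CC1` gives 12.5 nM, and the step is a 1.6-fold higher number from compound 1 to compound 3 (0.21 log units; within the scatter). Compound 2 `CCCC(=O)N1CCC(NS(=O)(=O)c2ccc(NC(=O)c3ccoc3)c3ccccc23)CC1` gives 1520 nM, so the step is a 75-fold lower number from compound 2 to compound 3 (1.87 log units; beyond the scatter). Compound 4 `CCCC(=O)N1CCC(NS(=O)(=O)c2ccc(NC(=O)c3cccnc3)c3ccccc23)CC1` carries the change (pyridin-3-yl in place of 1-methyl-1H-imidazol-2-yl on a carbonyl carbon). Within the data shown here, two measured steps bear on it: a 120-fold higher number from compound 1 to compound 2 (2.08 log units; beyond the scatter), a five-membered ring in place of phenyl, and a 1.6-fold higher number from compound 1 to compound 3 (0.21 log units; within the scatter), a different five-membered ring in place of phenyl. Pyridin-3-yl, like the phenyl of compound 1, is a six-membered aromatic ring, and compound 1 gives 12.5 nM, close to compound 3. The expected step is therefore a 1.4-fold lower number from compound 3 to compound 4 (0.13 log units; within the scatter), nothing beyond the scatter. Compound 4 is estimated at 15 nM, within a range from 5 nM to 60 nM.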

Compound 4, half-maximal inhibitory concentration: 885 nM
Estimate against measurement, compound 4: 59-fold (1.77 log units) below, outside the stated range (above it).
By their numbers in this assay, from the lowest: compounds 1 and 3 (each within the scatter of the next); then compounds 4 and 2 (each within the scatter of the next).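

Ring size alone does not set the number on this carbonyl carbon: pyridin-3-yl is six-membered like phenyl, yet the change gives a 71-fold higher number from compound 1 to compound 4 (1.85 log units; beyond the scatter) and also a 43-fold higher number from compound 3 to compound 4 (1.64 log units; beyond the scatter). Its number instead stays close to that of the five-membered furan-3-yl ring (with a 1.7-fold lower number from compound 2 to compound 4 (0.23 log units; within the scatter)), so each ring size now appears on both sides of the gap, with phenyl and 1-methyl-1H-imidazol-2-yl on one side and pyridin-3-yl and furan-3-yl on the other.

From the compounds shown here alone, how a saturated ring such as cyclohexyl, or an open alkyl chain such as butyl, would fare on this carbonyl carbon remains open. No measurement at hand explains the split.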